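Dropping the chloromethyl from the urea chain of compound 2

The compounds below may be only part of what the source reports. "The series", "measured", "known", "first", "only" and "open" are said of these compounds alone.

Compound 1 `Cc1ccccc1OS(=O)(=O)c1cccc(NC(=O)NCCCCl)c1`: 21000 nM
Compound 2 `Cc1ccccc1NS(=O)(=O)c1cccc(NC(=O)NCCCCl)c1`: 42000 nM
Compound 3 `CCCc1ccccc1NS(=O)(=O)c1cccc(NC(=O)NCCCCl)c1`: 15000 nM

All three were tested in a functional assay on HT-29 cells (Homo sapiens) for cytotoxicity, read by sulforhodamine B assay, with a stated time of 48 h; a lower number here means a stronger inhibitor, a higher number a weaker inhibitor. For the measured compounds named here, compound 2 gives the highest number of the three, although compound 1 lies within the scatter of it, with a 2.0-fold higher number from compound 1 to compound 2 (0.30 log units; within the scatter); the only step beyond the scatter is a 2.8-fold lower number from compound 2 to compound 3 (0.45 log units; beyond the scatter). Compound 4 `CCNC(=O)Nc1cccc(S(=O)(=O)Nc2ccccc2C)c1` differs from compound 2 at the other end of the molecule: hydrogen in place of chloromethyl on a saturated chain carbon, two bonds along the chain from an amide-type nitrogen. Neither measured step touches this chain; both alter the group on the sulfonyl sulfur. With nothing to lean on, no step beyond the scatter is expected, and the estimate is wide. Compound 4 is expected to give about 70000 nM, within 25000 nM to 250000 nM, that is a 1.7-fold higher number from compound 2 to compound 4 (0.22 log units; within the scatter).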

Compound 4, half-maximal inhibitory concentration: 102000 nM
Beside the measured number, compound 4's estimate is 1.5-fold (0.16 log units) below it; low and high end bracket the measured number.
By their numbers in this assay, from the lowest: compounds 3, 1 and 2 (each within the scatter of the next, the first and the last beyond it); then compound 4.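

For the compounds shown here, the earlier steps all changed the group on the sulfonyl sulfur, so this is the first reading on the urea chain. In this assay, cutting 3-chloropropyl back to ethyl gives a 2.4-fold higher number from compound 2 to compound 4 (0.39 log units; beyond the scatter), so this end of the molecule also affects the number, and the shorter chain without chlorine is the weaker inhibitor. No evidence shown explains this shift.

Going by these compounds, whether the chlorine or the chain length matters stays open. An amine or a hydroxyl in place of the chlorine on the full chain would help separate the two.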